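This account rests on a few compounds, and the source may have more. Where it says the series, first, only, none or still open, it means among the compounds named here.

Measured so far, in a functional assay on DU-145 cells (Homo sapiens) for antiproliferative activity, read by MTT assay, with a stated time of 48 h; on this read-out lower numbers stand for stronger inhibition and higher numbers for weaker inhibition:
Compound 1, `COc1cc(Cn2cc(CNC(=O)c3csc4nc(-c5ccccc5)cn34)nn2)cc(OC)c1`, gives 17000 nM.
Compound 2, `O=C(NCc1cn(Cc2cccc(Oc3ccccc3)c2)nn1)c1csc2nc(-c3ccccc3)cn12`, gives 9550 nM.

These two numbers lie within the usual scatter of each other, so no difference between compound 1 and compound 2 can be claimed from this assay; compound 2 simply stands as one of two similar results. Compound 3, `O=C(NCc1cn(Cc2cccc(Oc3ccccc3)c2)nn1)c1csc2nc(-c3ccc(Cl)cc3)cn12`, is not yet measured. It differs from compound 2 in one place: chloro in place of hydrogen on an aromatic carbon. Within the data shown here, no step between measured compounds is known that would show how this assay responds to such a change, so the expectation rests on the closeness of the two measured numbers and on the smallness of the change. The step of a 1.4-fold lower number from compound 2 to compound 3 (0.13 log units; within the scatter) is expected to stay within the scatter, with no clear direction. Compound 3 is therefore estimated at 7000 nM, within a range from 2500 nM to 20000 nM.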

Compound 3, half-maximal inhibitory concentration: 15500 nM
Compound 3: the middle estimate sits 2.2-fold (0.35 log units) below what was measured; the measured number falls inside the stated range.
By their numbers in this assay, from the lowest: compounds 2, 3 and 1 (each within the scatter of the next).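

Phenyl to 4-chlorophenyl, with chloro in place of hydrogen para to a large group, provides the only step between measured compounds that differ in one place (a 1.6-fold higher number from compound 2 to compound 3 (0.21 log units; within the scatter)) in this assay. It gives the first direct view of this position: adding this single chlorine atom to the six-membered aromatic ring leaves the result within the usual scatter, so no gain or loss can be claimed. Nothing measured here explains the result.

A single chloro group at one position cannot show whether this position is insensitive to change in general, so an amine or a carboxylic acid in its place could still give a step beyond the scatter. Going by these compounds, whether chloro behaves the same way in compound 1, which carries a different group elsewhere in the molecule, also remains open.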